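The source may report more compounds than this note shows. Statements on the series, on what has been measured and on what is new or still open speak of the compounds shown alone.

Measured in a functional assay on DU-145 cells (Homo sapiens) for inhibition, read by trypan blue exclusion, with a stated time of 96 h; a higher number here means a weaker inhibitor of growth, a lower number a stronger inhibitor of growth:
- compound 1 `Cc1ccc(S(=O)(=O)/C(=C/c2sccc2C)C(=O)c2ccc(Cl)cc2)cc1`: 10000 nM
- compound 2 `Cc1ccc(S/C(=C/c2cc(Cl)cc(Cl)c2Cl)C(=O)c2ccc(Cl)cc2)cc1`: 50000 nM
- compound 3 `Cc1ccc(CS(=O)(=O)/C(=C/c2ccc(N(C)C)cc2)C(=O)c2ccc(Cl)cc2)cc1`: 50000 nM

Compound 2 is level with compound 3 at the digits shown, and the two share the highest number of the three. Compound 1 has a lower number, beyond the scatter. Compound 4 `Cc1ccc(S/C(=C/c2ccc[nH]2)C(=O)c2ccc(Cl)cc2)cc1` is still unmeasured. It has 1H-pyrrol-2-yl in place of 2,3,5-trichlorophenyl on a double-bonded chain carbon bound to a double-bonded chain carbon. For the measured compounds named here, no measured pair differs in one place, so the guide is weak. Compound 1, which also has a five-membered aromatic ring with 1 hetero atom, gives 10000 nM, and this suggests a moderate gain in this assay. The expected change is a 3.3-fold lower number from compound 2 to compound 4 (0.52 log units; beyond the scatter), toward a lower number. For compound 4 the estimated value is 15000 nM, with an expected range of 2500 nM to 60000 nM.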

Compound 4, concentration for 50% growth inhibition: 10000 nM
The estimate for compound 4 lay 1.5-fold (0.18 log units) above the measured number; measured number inside the range.
By their numbers in this assay, from the lowest: compounds 1 and 4 (each within the scatter of the next); then compounds 2 and 3 (each within the scatter of the next).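

In this assay, replacing 2,3,5-trichlorophenyl with 1H-pyrrol-2-yl gives a 5.0-fold lower number from compound 2 to compound 4 (0.70 log units; beyond the scatter) on a double-bonded chain carbon bound to a double-bonded chain carbon. For the compounds shown here, this is the first single-place step in the set, and it shows that the group at this position can alter growth inhibition. Nothing available explains the change.

On these data alone, the swap alters the ring size, the chlorine atoms and the ring's hydrogen-bond donor together, so their separate contributions remain open. Plain phenyl or 1-methylpyrrol-2-yl at this place would help separate them.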